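Extending the isoxazole chain on an acetylated uridine core

The source may hold more compounds than are shown below. What is called first, only, known or untested is meant among the compounds shown, and "the series" means these compounds.

Measured compounds:
Compound 1, `CC(=O)OC[C@H]1O[C@@H](n2cc(-c3cn(Cc4ccccc4)nn3)c(=O)[nH]c2=O)C[C@@H]1OC(C)=O`: 92.1%
Compound 2, `CCCCCCCCc1cc(-c2cn([C@H]3C[C@H](O)[C@@H](CO)O3)c(=O)[nH]c2=O)on1`: 77.3%
Compound 3, `CC(=O)OC[C@H]1O[C@@H](n2cc(-c3cc(C)no3)c(=O)[nH]c2=O)C[C@@H]1OC(C)=O`: 92.4%

Three compounds share a uracil nucleoside core and were tested in a functional assay on PC-3 cells (Homo sapiens) for cytotoxicity, read by sulforhodamine B assay, tested at 10 uM; on this read-out lower numbers stand for less inhibition and higher numbers for more inhibition at the one concentration tested (going by the name of the read-out). Compound 3 with `CC(=O)OC[C@H]1O[C@@H](n2cc(-c3cc(C)no3)c(=O)[nH]c2=O)C[C@@H]1OC(C)=O` gives 92.4% in this assay, the highest number of the three. Compound 1 gives 92.1%, a number that lies within the usual scatter of compound 3, so the two cannot be told apart. Compound 2, which carries a free sugar rather than acetates and an octyl chain on its ring, gives 77.3%, a number that falls beyond the scatter below compound 3.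

Compound 4, `CCCCCc1cc(-c2cn([C@H]3C[C@H](OC(C)=O)[C@@H](COC(C)=O)O3)c(=O)[nH]c2=O)on1`, has not yet been measured. Relative to compound 3 the change is butyl in place of hydrogen on a saturated chain carbon bound to an aromatic carbon. For the measured compounds named here, both acetylated compounds, compound 1 and compound 3, sit close together in this assay, while the one compound with a long chain, compound 2, also differs in its sugar, so the chain itself cannot be separated out. Compound 4 is therefore expected to stay near compound 3, with the step from compound 3 to compound 4 estimated at a number 4.4 percentage points lower from compound 3 to compound 4 (within the scatter), at most a small decrease and possibly none beyond the scatter. Compound 4 is estimated to give 88% in this assay, within a range of 72% to 97%.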

Compound 4, a percentage reported as inhibition, at one concentration (the size of the read-out at that concentration, not a potency): 93.9%
For compound 4 the middle estimate is 5.9 percentage points below the measured one; low and high end bracket the measured number.
By their numbers in this assay, from the lowest: compound 2; then compounds 1, 3 and 4 (each within the scatter of the next).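

In this assay, for the compounds shown here, the change from 3-methyl-1,2-oxazol-5-yl to 3-pentyl-1,2-oxazol-5-yl gives a number 1.5 percentage points higher from compound 3 to compound 4 (within the scatter), the first step in this set that isolates a single place, as the earlier compounds offered no such pair. With the acetylated sugar kept constant, butyl in place of hydrogen on a saturated chain carbon bound to an aromatic carbon therefore produces no change that can be told from the usual scatter at the one concentration tested. The compounds shown offer no independent measurement that could explain this result.

Compound 2 differs from compound 4 in both its chain and its sugar. The compounds shown do not settle whether an octyl chain on the acetylated sugar would stay within the scatter of compound 4, or whether the free sugar with a pentyl chain would match it. Also open, as far as these compounds go, is how this position would respond to a chain ending in an amine or a carboxylic acid, and a single-concentration reading cannot show whether compound 3 and compound 4 differ in potency.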